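Hydroxybutenyl and hydroxybutynyl side chains on two cores

The compounds below may be only part of what the source reports. "The series", "measured", "known", "first", "only" and "open" are said of these compounds alone.

Measured so far:
Compound 1, `Nc1nc(O)c2ncn(C/C=C\CO)c2n1`: in a functional assay on L1210 cells (Mus musculus) for inhibition (on this read-out higher numbers stand for weaker inhibition and lower numbers for stronger inhibition), compound 1 gives 680000 nM.
Compound 3, `Nc1nc(O)c2ncn(CC#CCO)c2n1`: in this assay compound 3 gives 210000 nM.
Compound 2, `Nc1ccn(C/C=C\CO)c(=O)n1`: in this assay compound 2 reaches only a limit, > 1000000 nM.

Compound 1 and compound 3 share one core; compound 2 carries another, and the difference between the two cores is not broken down here. Within the shared core the single change 3-hydroxyprop-1-yn-1-yl in place of 3-hydroxyprop-1-en-1-yl on a saturated chain carbon bound to an aromatic nitrogen gives the step of a 3.2-fold lower number from compound 1 to compound 3 (0.51 log units; beyond the scatter). Compound 4, `Nc1ccn(CC#CCO)c(=O)n1`, is not yet measured and stands to compound 2 as compound 3 stands to compound 1, the change being (3-hydroxyprop-1-yn-1-yl in place of 3-hydroxyprop-1-en-1-yl on a saturated chain carbon bound to an aromatic nitrogen), the same change at the same place. For compound 2 the value is a limit, (the limit of > 1000000 nM in this assay, at which 1 of the 3 values shown sits). Beside a 3.2-fold lower number from compound 1 to compound 3 (0.51 log units; beyond the scatter), a step of similar size is expected, an at least 1.1-fold lower number from compound 2 to compound 4 (0.04 log units; that floor lies within the scatter), resting on that measured step from compound 1 to compound 3. With compound 2 known only as a limit, the starting point is open, and compound 4 may itself be reported as a limit. Compound 4 is estimated at 900000 nM, expected between 300000 nM and 3000000 nM.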

Compound 4, half-maximal inhibitory concentration: > 550000 nM
Compound 4 was reported as a limit; the forecaster's own chance of this, stated with the estimate: 55%; the middle value does not contradict the limit.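

In this assay compound 2 is only a limit, > 1000000 nM. Compound 4 is likewise only a limit, > 550000 nM, and these two limits leave no readable step between compound 2 and compound 4. Going by these compounds, whether 3-hydroxyprop-1-yn-1-yl in place of 3-hydroxyprop-1-en-1-yl lowers the number on this core, as it does from compound 1 to compound 3, stays open.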